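Ether side-chain variation on the shared core

A few compounds are considered here, and "the series" means these few. Any claim that something is new, unique, unknown or untested is made for them only; others in the source may bear on it.

Compound 1 `Nc1ccc2cccc(OCCC(F)(F)F)c2n1` carries a 3,3,3-trifluoropropyl ether on the shared core; in an assay on cells with melanin-concentrating hormone receptor 1 (Homo sapiens) as the target, read by radioligand binding (a higher number here means a weaker inhibitor, a lower number a stronger inhibitor), compound 1 gives 722 nM, the highest number among the three measured compounds. Compound 3 `CC(C)Oc1cccc2ccc(N)nc12` gives 437 nM, and a 1.7-fold lower number from compound 1 to compound 3 (0.22 log units; within the scatter), so one alkyl ether in place of another leaves the number where it is. Compound 2 `Nc1ccc2cccc(OCC3CC4CCC3C4)c2n1` gives 137 nM, a lower number than compound 1 by a margin beyond the scatter. Compound 4 `Nc1ccc2cccc(OCC3CCCO3)c2n1` differs from compound 1 by oxolan-2-yl in place of 2,2,2-trifluoroethyl on a saturated chain carbon bound to an oxygen on an aromatic ring. Among the compounds with values here, the only step bearing directly on this change stayed within the scatter, while the saturated ring of compound 2 goes with a lower number; a modest drop is therefore expected, a 1.8-fold lower number from compound 1 to compound 4 (0.26 log units; within the scatter). For compound 4 the expected value in this assay is 400 nM, within 150 nM to 1200 nM.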

Compound 4, half-maximal inhibitory concentration: > 2000 nM
Compound 4 ended at the assay's limit; the forecaster's own chance of this, stated with the estimate: 3%; at least 5.0-fold (0.69 log units) between middle value and limit.
By their numbers in this assay, from the lowest: compound 2; then compounds 3 and 1 (each within the scatter of the next). At a limit, above all of these: compound 4.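

In this assay compound 4 gives > 2000 nM, which is a limit of the assay and not a number: the limit of > 2000 nM in this assay, at which 1 of the 4 values shown sits. Unlike the earlier swap of alkyl ethers, a 1.7-fold lower number from compound 1 to compound 3 (0.22 log units; within the scatter), this change at the oxygen on the aromatic ring moves the result beyond the scatter: an at least 2.7-fold higher number from compound 1 to compound 4 (0.44 log units; beyond the scatter), and an at least 4.5-fold higher number from compound 3 to compound 4 (0.66 log units; beyond the scatter). A saturated ring in the side chain therefore does not by itself go with a low number, since compound 2 gives 137 nM.

Whether the ring oxygen of compound 4 accounts for the difference stays open. A cyclopentylmethyl ether on the shared core would separate the ring from its oxygen.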